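The source may report more compounds than this note shows. Statements on the series, on what has been measured and on what is new or still open speak of the compounds shown alone.

Measured so far in an ADME assay on Li23 cells (Homo sapiens) for cytotoxicity, read by WST assay; on this read-out lower numbers stand for higher toxicity in this test and higher numbers for lower toxicity in this test:

Compound 1 `CN(C(=O)c1ccccc1)c1ccc(C(O)(C(F)(F)F)C(F)(F)F)cc1` gives 65000 nM in this assay.
Compound 2 `Cc1cc(N(C)C(=O)c2ccccc2)ccc1C(O)(C(F)(F)F)C(F)(F)F` gives 87000 nM in this assay.
Compound 3 `CN(C(=O)c1ccccc1)c1ccc(C(OCCO)(C(F)(F)F)C(F)(F)F)cc1` gives only a limit of the assay, > 20000 nM in this assay, not a number.

Among the compounds with values here, compound 1 holds the lowest of the two numbers; its nearest neighbour is compound 2, with a 1.3-fold higher number from compound 1 to compound 2 (0.13 log units; within the scatter), which is the only readable step here. For compound 3 the value is a limit (the limit of > 20000 nM in this assay, at which 1 of the 3 values shown sits), so the step that the limit leaves unreadable from compound 1 to compound 3 cannot be read in size.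

Compound 4 `CN(c1ccc(C(O)(C(F)(F)F)C(F)(F)F)cc1)S(=O)(=O)c1ccccc1` is not yet measured. It differs from compound 1 as follows: phenylsulfonyl in place of benzoyl on a nitrogen on an aromatic ring. Neither measured step touches the group on that nitrogen: one varies a hydrogen on an aromatic carbon, the other a hydrogen on the oxygen of the saturated carbon. Within the data shown here, nothing measured therefore bears directly on the exchange, and no direction can be derived from the series; the only readable step in this assay lay within the scatter.

For compound 4 a change within the scatter is expected, a 1.1-fold lower number from compound 1 to compound 4 (0.03 log units; within the scatter). The estimate for compound 4 in this assay is 60000 nM, with a range from 25000 nM to 130000 nM.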

Compound 4, half-maximal cytotoxic concentration: 16000 nM
Estimate against measurement, compound 4: 3.8-fold (0.57 log units) above; measured number outside the range, below it.
By their numbers in this assay, from the lowest: compound 4; then compounds 1 and 2 (each within the scatter of the next).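

In this assay, within the data shown here, the group on the nitrogen on an aromatic ring is the first place where a single exchange gives a step beyond the scatter: phenylsulfonyl in place of benzoyl gives a 4.1-fold lower number from compound 1 to compound 4 (0.61 log units; beyond the scatter). The number falls on this exchange, which on this read-out stands for higher toxicity in this test, so this position is not indifferent to the group it carries, whereas the methyl exchange on the aromatic carbon gave a 1.3-fold higher number from compound 1 to compound 2 (0.13 log units; within the scatter). Nothing measured here says what in phenylsulfonyl accounts for this step, and it remains a single pair of compounds.

As far as these compounds go, whether the step depends on the sulfonyl link or on the phenyl ring stays open, as does the outcome with a smaller group on that nitrogen, such as methylsulfonyl or acetyl, or with the same exchange on the methyl-bearing core of compound 2. The step to compound 3 cannot be read, and how the 2-hydroxyethyl group compares remains unsettled, since its value is a limit: the limit of > 20000 nM in this assay, at which 1 of the 4 values shown sits.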